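This account rests on a few compounds, and the source may have more. Where it says the series, first, only, none or still open, it means among the compounds named here.

Working notes on the shared core of compound 1 `OC(CCn1nc2c(Br)c(Br)c(Br)c(Br)c2n1)c1cccc(Br)c1`, read in a functional assay on MCF7 cells (Homo sapiens) for antiproliferative activity, read by MTT assay, with a stated time of 24 h, tested at 50 uM; a lower number here means a stronger effect, a higher number a weaker effect of the compound at the concentration tested. Compound 1 gives 14%. Compound 2 `COc1cccc(C(O)CCn2nc3c(Br)c(Br)c(Br)c(Br)c3n2)c1` gives 22%, and compound 3 `C[C@H](O)CCn1nc2c(Br)c(Br)c(Br)c(Br)c2n1` gives 105%. Compound 2 stands second highest of the three, nearest to compound 1 and furthest from compound 3. Within the data shown here, the one measured step, a number 8 percentage points higher from compound 1 to compound 2 (within the scatter), is a methoxy in place of bromo on an aromatic carbon and lies within the scatter.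

Compound 4 `OC(CCn1nc2c(Br)c(Br)c(Br)c(Br)c2n1)c1ccc(Cl)cc1` is still to be measured; it differs from compound 2 as 4-chlorophenyl in place of 3-methoxyphenyl on a saturated chain carbon bound to an oxygen on a saturated carbon and a saturated chain carbon. The step from compound 1 to compound 2 bears on it, since both exchange one substituent on a six-membered aromatic ring of carbon only, and compounds 1 and 2 both sit far from compound 3. No step beyond the scatter is expected in this assay. The expected step is a number 2 percentage points lower from compound 2 to compound 4 (within the scatter). Compound 4 is estimated at 20%, between 5% and 45%.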

Compound 4, a percentage reported as activity, at one concentration (the size of the read-out at that concentration, not a potency): 19%
For compound 4 the middle estimate is 1 percentage points above the measured one; low and high end bracket the measured number.
By their numbers in this assay, from the lowest: compounds 1, 4 and 2 (each within the scatter of the next); then compound 3.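

In this assay, the step of a number 3 percentage points lower from compound 2 to compound 4 (within the scatter) and the step of a number 5 percentage points higher from compound 1 to compound 4 (within the scatter) both stay within the scatter. The level seen with the 3-bromophenyl and 3-methoxyphenyl groups therefore also holds for 4-chlorophenyl, so this position tolerates a change in both the substituent and the name-given ring location without a readable shift. No measurement at hand accounts for this flat result.

Still open, on these data alone, is whether a phenyl group carrying an amine or a carboxylic acid would stay at this level. Also open, as far as these compounds go, is where a longer saturated chain in this place would fall, given compound 3 at 105%.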